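Furan-3-yl in Place of Cyclohexyl on the Cyclopropane

The source may report more compounds than this note shows. Statements on the series, on what has been measured and on what is new or still open speak of the compounds shown alone.

Compound 1 `O=C([C@@H]1C[C@H]1c1ccccc1)N(CCNCC1CCCCC1)c1ccc(-c2ccccc2)cc1` gives 6.6 nM in a functional assay for agonist activity at G protein-coupled receptor 88 (Homo sapiens), read by HTRF and cAMP accumulation; a lower number here means that less compound is needed, a higher number that more compound is needed for the effect. Compound 2 `CC[C@H](C)[C@H](N)CN(C(=O)[C@@H]1C[C@H]1C1CCCCC1)c1ccc(-c2ccccc2)cc1` reaches only a limit in this assay, reported as > 25000 nM, so no number is known for it; the limit of > 25000 nM in this assay, at which 1 of the 2 values shown sits, marks where it sits. Compound 3 `CC[C@H](C)[C@H](N)CN(C(=O)[C@@H]1C[C@H]1c1ccoc1)c1ccc(-c2ccccc2)cc1` changes one group: furan-3-yl in place of cyclohexyl on a saturated ring carbon. Within the data shown here, no measured step between two compounds covers this change, and compound 1 differs from compound 2 at more than one place. The step of an at least 3.1-fold lower number from compound 2 to compound 3 (0.49 log units; beyond the scatter) is expected to lower the needed amount somewhat. Compound 3 is expected near 8000 nM, within 800 nM to 30000 nM.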

Compound 3, half-maximal effective concentration: 580 nM
For compound 3 the middle estimate is 14-fold (1.14 log units) above the measured one, outside the stated range (below it).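

Compound 2 is known only as a limit, so this change has a lower bound on its size and no exact figure: the limit of > 25000 nM in this assay, at which 1 of the 3 values shown sits. Furan-3-yl in place of cyclohexyl on this saturated ring carbon gives an at least 43-fold lower number from compound 2 to compound 3 (1.63 log units; beyond the scatter). This position of the three-membered ring is therefore sensitive to the group it carries, and a five-membered aromatic ring with one oxygen gives a measurable value in this assay.

The compounds shown cannot separate the role of the ring oxygen from that of aromaticity. A thiophen-3-yl group at this carbon would help to tell them apart.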